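Removing the Hydroxy Group from a Thiazole Amine Lipoxygenase Inhibitor

The source may report more compounds than this note shows. Statements on the series, on what has been measured and on what is new or still open speak of the compounds shown alone.

Compound 1 `Oc1cccc(Nc2nc(-c3ccc(Cl)cc3)cs2)c1` was tested in an assay on isolated protein for inhibition of Polyunsaturated fatty acid 5-lipoxygenase (Homo sapiens), with stated times of 15 min and 10 min (a lower number here means a stronger inhibitor, a higher number a weaker inhibitor), where compound 1 gives 5600 nM. Among the measured compounds shown here, this is the lowest of the two numbers measured so far; its nearest neighbour is compound 2 `Oc1cccc(Nc2nc(-c3ccccc3)cs2)c1`, which in this assay gives 8300 nM. The step of a 1.5-fold higher number from compound 1 to compound 2 (0.17 log units; within the scatter) comes from a hydrogen in place of chloro on an aromatic carbon, and it lies within the scatter, so the two compounds cannot be told apart on this evidence.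

Compound 3 `Clc1ccc(-c2csc(Nc3ccccc3)n2)cc1` has not yet been measured in this assay. It differs from compound 1 in a single place: hydrogen in place of hydroxy on an aromatic carbon. For the measured compounds named here, no measured step touches this hydroxy group, since the only step available concerns the chloro on the ring bearing it, and that step was within the scatter. There is therefore no direct evidence on which to expect a large shift in either direction for compound 3. With that in mind, compound 3 is expected to show a 1.6-fold higher number from compound 1 to compound 3 (0.21 log units; within the scatter), leaning slightly toward a higher number, and its value in this assay is estimated at 9000 nM, within a range of 3500 nM to 25000 nM.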

Compound 3, half-maximal inhibitory concentration: 5600 nM
Estimate against measurement, compound 3: 1.6-fold (0.21 log units) above, within the range that was stated.
By their numbers in this assay, from the lowest: compounds 1, 3 and 2 (each within the scatter of the next).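

In this assay, among the compounds shown here, the exchange of hydroxy for hydrogen gives no change at the digits printed from compound 1 to compound 3 (within the scatter) and so provides the first reading at this position, on an aromatic carbon meta to a large group. In this pair, the hydroxy, with the one hydrogen-bond donor and one hydrogen-bond acceptor counted for it, can leave the aromatic ring with no change beyond the scatter, so it is not needed for the level of inhibition seen with the chloro group in place. The finding rests on this single pair, and no separate measurement here accounts for it.

The compounds shown leave open whether the hydroxy can also be removed without consequence when the chloro group is absent, since the exchange of chloro for hydrogen has been read only with the hydroxy present and the exchange of hydroxy for hydrogen only with the chloro present. They also leave open whether a methoxy group, an amine or a carboxylic acid on the same aromatic carbon would move the number beyond the scatter, or whether this position stays as insensitive as the hydrogen exchange suggests.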